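This account rests on a few compounds, and the source may have more. Where it says the series, first, only, none or still open, it means among the compounds named here.

Measured so far in an assay on cells for antagonist activity at transient receptor potential cation channel subfamily V member 1 (Homo sapiens), read by FLIPR and calcium flux, with a stated time of 6 min; a lower number here means a stronger inhibitor, a higher number a weaker inhibitor:
compound 1 `CCOc1nc(C(C)(C)C)ccc1CNC(=O)C(C)c1ccc(NS(C)(=O)=O)c(F)c1` gives 14.8 nM;
compound 2 `CC(C)Oc1nc(C(C)(C)C)ccc1CNC(=O)C(C)c1ccc(NS(C)(=O)=O)c(F)c1` gives 2.3 nM;
compound 3 `CCCCSc1nc(C(C)(C)C)ccc1CNC(=O)C(C)c1ccc(NS(C)(=O)=O)c(F)c1` gives 3.2 nM.

Within the series, the step of a 6.4-fold lower number from compound 1 to compound 2 (0.81 log units; beyond the scatter) is described as methyl in place of hydrogen on a saturated chain carbon bound to an oxygen on an aromatic ring and a saturated chain carbon. The core of compound 3 differs from the core of compound 1 as butylsulfanyl in place of ethoxy on an aromatic carbon, with a 4.6-fold lower number from compound 1 to compound 3 (0.67 log units; beyond the scatter); between compound 2 and compound 3 the step is a 1.4-fold higher number from compound 2 to compound 3 (0.14 log units; within the scatter).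

Compound 4 `CCCCCSc1nc(C(C)(C)C)ccc1CNC(=O)C(C)c1ccc(NS(C)(=O)=O)c(F)c1` is not yet measured. It differs from compound 3 as methyl in place of hydrogen on a saturated chain carbon, four bonds along the chain from a sulfur. Going by the values given here, this is the same kind of change as the one from compound 1 to compound 2, but not the same: there the added carbon sits on a saturated chain carbon bound to an oxygen on an aromatic ring and a saturated chain carbon, whereas here it sits on a saturated chain carbon, four bonds along the chain from a sulfur. The earlier step was measured on a different chain and position, so it is only a loose guide.

For compound 4 in this assay a step of a 1.3-fold lower number from compound 3 to compound 4 (0.11 log units; within the scatter) is expected, smaller than a 6.4-fold lower number from compound 1 to compound 2 (0.81 log units; beyond the scatter) because the change lies further out on the chain and because a 1.4-fold higher number from compound 2 to compound 3 (0.14 log units; within the scatter) is already small. Compound 4 is estimated at 2.5 nM, within 1 nM to 7 nM.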

Compound 4, inhibition constant: 3.1 nM
Compound 4: middle estimate off by 1.2-fold (0.09 log units), on the low side; the range from low to high includes it.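

In this assay the change of methyl in place of hydrogen does not carry over in size from one core to the other: the same change on two cores in this assay, a 6.4-fold lower number (0.81 log units; beyond the scatter) from compound 1 to compound 2 and a 1.0-fold lower number (0.01 log units; within the scatter) from compound 3 to compound 4, 6.2-fold (0.79 log units) apart, beyond the scatter of two such steps

On the sulfur-linked chain the step is a 1.0-fold lower number from compound 3 to compound 4 (0.01 log units; within the scatter); pentylsulfanyl in place of isopropoxy gives a 1.3-fold higher number from compound 2 to compound 4 (0.13 log units; within the scatter), and pentylsulfanyl in place of ethoxy gives a 4.8-fold lower number from compound 1 to compound 4 (0.68 log units; beyond the scatter). With a single pair on each core, and the methyl on a different chain and at a different place in each pair, these data do not separate the role of the sulfur from that of chain length or of the place of the methyl, and they give no rule for other cores.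

From the compounds shown here alone, it remains open whether a longer chain such as hexylsulfanyl stays level with compound 4, and whether isopropylsulfanyl tracks isopropoxy. Going by these compounds, how an amine on that same aromatic carbon would compare with these ethers and thioethers is also open.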